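The source may hold more compounds than are shown below. What is called first, only, known or untested is meant among the compounds shown, and "the series" means these compounds.

Three compounds of a shared core, drawn here as compound 1 `CN1CCN(S(=O)(=O)c2ccc(NC(=O)c3ccccc3)c3ccccc23)CC1`, compound 2 `CCOC(=O)N1CCC(NS(=O)(=O)c2ccc(C(=O)NC3CCCCC3)c3ccccc23)CC1` and compound 3 `CCC(=O)N1CCC(NS(=O)(=O)c2ccc(NC(=O)c3ccccc3C)c3ccccc23)CC1`, have been examined in an assay on L1.2 cells for binding affinity to C-C chemokine receptor type 8 (Homo sapiens); a lower number here means a stronger inhibitor, a higher number a weaker inhibitor. Compound 1 reaches only a limit of the assay, at > 30000 nM. Compound 2 gives 9.5 nM in this assay. Compound 3 gives 2.5 nM, which is the lowest of the two numbers that were obtained, and its gap to compound 2 lies beyond the usual scatter of the measurement.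

The account now follows the step from compound 3 to compound 4 `Cc1ccccc1C(=O)Nc1ccc(S(=O)(=O)NC2CCN(C(=O)NC(C)C)CC2)c2ccccc12`, which has not yet been measured in this assay. The difference between the two structures is counted as isopropylamino in place of ethyl on a carbonyl carbon: the ethyl leaves and isopropylamino enters on a carbonyl carbon whose other neighbours are an amide-type nitrogen in a ring, so that the propanoyl becomes isopropylcarbamoyl.

Going by the values given here, no pair of measured compounds shows this change, so the size of the step can only be expected. Compound 4 is expected to keep the affinity of compound 3 within the scatter, with a step of a 1.6-fold higher number from compound 3 to compound 4 (0.20 log units; within the scatter) in this assay. The estimate for compound 4 is 4 nM, with a range from 1.5 nM to 12 nM.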

Compound 4, inhibition constant: 77.7 nM
Beside the measured number, compound 4's estimate is 19-fold (1.29 log units) below it; measured number outside the range, above it.
By their numbers in this assay, from the lowest: compound 3; then compound 2; then compound 4. At a limit, above all of these: compound 1.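

In this assay, the carbonyl carbon of the 1-propanoylpiperidin-4-yl group proves sensitive to what it carries, since isopropylamino in place of ethyl gives a 31-fold higher number from compound 3 to compound 4 (1.49 log units; beyond the scatter). This is the first step among the compounds shown that changes one place only, so it is the first direct reading of this position, and it shows that the propanoyl to isopropylcarbamoyl change is a large loss rather than a neutral exchange. No measurement shown bears on what lies behind this loss.

The compounds shown do not separate the entering nitrogen from the branched carbon chain that comes with it. From the compounds shown here alone, a methylamino group or an isopropyl group on the same carbonyl carbon would tell these two apart, and how either would read in this assay remains open.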